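Swapping a Hydroxy for a Methyl on a Shared Core

A few compounds are considered here, and "the series" means these few. Any claim that something is new, unique, unknown or untested is made for them only; others in the source may bear on it.

For the measured compounds named here, in a functional assay on A549 cells (Homo sapiens) for inhibition, read by MTT assay, with a stated time of 72 h (on this read-out lower numbers stand for stronger inhibition and higher numbers for weaker inhibition), compound 3 `Cc1ccc2nc(-c3ccc(NCc4cn(Cc5cc(=O)oc6cc(O)ccc56)nn4)cc3)sc2c1` gives 16200 nM, the lowest of the two numbers measured so far. Compound 1 `CCCC1CCC(c2ccc(-c3cn(Cc4cc(=O)oc5cc(O)ccc45)nn3)cc2)CC1` gives 41000 nM in this assay, a gap beyond the usual scatter. Compound 2 `O=c1cc(Cn2cc(CNS(=O)(=O)c3ccc([N+](=O)[O-])cc3)nn2)c2ccc(O)cc2o1` reaches only a limit in this assay, > 100000 nM, so no number is known for it. That is the limit of > 100000 nM in this assay, at which 1 of the 3 values shown sits. Compound 4 `Cc1ccc2c(Cn3cc(CNc4ccc(-c5nc6ccc(C)cc6s5)cc4)nn3)cc(=O)oc2c1` has not yet been measured. It differs from compound 3 by methyl in place of hydroxy on an aromatic carbon. Going by the values given here, no measured pair shows this change, so the size of the step is open, and the expectation for compound 4 in this assay is a shift no larger than the scatter, in either direction. Compound 4 is therefore estimated at 20000 nM, between 6000 nM and 70000 nM, an expected step of a 1.2-fold higher number from compound 3 to compound 4 (0.09 log units; within the scatter).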

Compound 4, half-maximal inhibitory concentration: 46200 nM
Beside the measured number, compound 4's estimate is 2.3-fold (0.36 log units) below it, within the range that was stated.
By their numbers in this assay, from the lowest: compound 3; then compounds 1 and 4 (each within the scatter of the next). At a limit, above all of these: compound 2.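

The change from hydroxy to methyl on this aromatic carbon gives a 2.9-fold higher number from compound 3 to compound 4 (0.46 log units; beyond the scatter) in this assay and so shows that the group at this position can shift the number. For the compounds shown here, the step is modest, but it is the first measured pair to isolate a single change on this core, and the lower number belongs to the hydroxy compound. Nothing measured here accounts for the step.

As far as these compounds go, whether a methoxy group, an amine or a chlorine atom on this carbon would stay nearer the hydroxy or the methyl remains open. So does whether the same change would give a similar step with a different side chain on the core.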